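The source may report more compounds than this note shows. Statements on the series, on what has been measured and on what is new or still open speak of the compounds shown alone.

Of the compounds shown here, two have so far been measured in a functional assay on HeLa cells (Homo sapiens) for antiproliferative activity, read by MTT assay, with a stated time of 48 h; on this read-out higher numbers stand for weaker inhibition and lower numbers for stronger inhibition. Compound 1 `COc1ccc2c(/C=C(\C)C(=O)c3cc(OC)c(OC)c([Se]C)c3)c[nH]c2c1` gives 21 nM. Compound 2 `COc1cc(C(=O)/C(C)=C/c2cn(C)c3ccccc23)cc([Se]C)c1OC` gives 63 nM, the highest of the two numbers and so the weaker inhibitor of the pair; its gap to compound 1 lies beyond the usual scatter of repeated runs. Compound 3 `COc1ccc2c(/C=C(\C)C(=O)c3cc(OC)c(OC)c([Se]C)c3)cn(C)c2c1` has not yet been measured. It differs from compound 2 in one place: methoxy in place of hydrogen on an aromatic carbon. Compound 3 therefore carries the same methoxy group that compound 1 has, while otherwise matching compound 2. Going by the values given here, no measured pair differs by only this change, so the size of the step cannot be read directly; the only guide is that compound 1, which also bears this methoxy, gives 21 nM. Compound 3 is expected to move toward compound 1, an estimated step of a 2.1-fold lower number from compound 2 to compound 3 (0.32 log units; beyond the scatter) toward lower numbers, likely beyond the scatter. In this assay compound 3 is expected to give about 30 nM, within a range of 12 nM to 80 nM.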

Compound 3, half-maximal inhibitory concentration: 32 nM
The estimate for compound 3 lay 1.1-fold (0.03 log units) below the measured number; the measured number falls inside the stated range.
By their numbers in this assay, from the lowest: compounds 1, 3 and 2 (each within the scatter of the next, the first and the last beyond it).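

Putting methoxy in place of hydrogen on the aromatic carbon, meta to a fused ring and para to a fused ring, gives a 2.0-fold lower number from compound 2 to compound 3 (0.29 log units; within the scatter) in this assay, so with methyl on the aromatic nitrogen this added group brings no clear change. Methyl in place of hydrogen on that nitrogen gives a 1.5-fold higher number from compound 1 to compound 3 (0.18 log units; within the scatter) in this assay, so with the methoxy present this swap also brings no clear change. Nothing available here explains either step.

Each step is known in one setting only: the methoxy step with methyl on the nitrogen, and the methyl step with methoxy on the ring. On these data alone, whether an amine or a chlorine atom on that aromatic carbon, or a longer chain such as propyl on the nitrogen, would shift the number beyond the scatter remains open.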